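Adding a methyl to the propyl chain of compound 2

The compounds below may be only part of what the source reports. "The series", "measured", "known", "first", "only" and "open" are said of these compounds alone.

Of the compounds shown here, two from this series have been measured in an ADME assay on the whole organism for inhibition, with Echinochloa crus-galli var. formosensis as the target, with a stated time of 4 days; on this read-out higher numbers stand for weaker inhibition and lower numbers for stronger inhibition. Compound 1 `CCCNc1nc(Cl)nc(N[C@@H](C)c2ccccc2)n1` gives 15100 nM, and compound 2 `CCCNc1nc(Cl)nc(N[C@H](C)c2ccccc2)n1` gives 33100 nM. Compound 2 therefore stands with the higher of the two numbers, separated from compound 1 by a 2.2-fold higher number from compound 1 to compound 2 (0.34 log units; beyond the scatter), the two differing only in configuration as drawn (the fact that compounds 1 and 2 differ only in the configuration as drawn).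

Compound 3 `CC[C@@H](C)Nc1nc(Cl)nc(N[C@H](C)c2ccccc2)n1` is not yet measured. It differs from compound 2 by methyl in place of hydrogen on a saturated chain carbon bound to a nitrogen on an aromatic ring and a saturated chain carbon. Within the data shown here, none of the measured steps concerns a change of this kind; the single measured step, from compound 1 to compound 2, involves configuration alone and offers no guide to methyl in place of hydrogen on the chain. With no directional evidence, the expectation for compound 3 is a number close to that of compound 2, a step of a 1.0-fold lower number from compound 2 to compound 3 (0.00 log units; within the scatter) that is not expected to exceed the scatter.

Compound 3 is therefore estimated at 33000 nM, within a range from 11000 nM to 100000 nM.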

Compound 3, half-maximal inhibitory concentration: 4570 nM
Compound 3: middle estimate off by 7.2-fold (0.86 log units), on the high side; the whole stated range lies above it.
By their numbers in this assay, from the lowest: compound 3; then compound 1; then compound 2.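

In this assay, methyl in place of hydrogen on a saturated chain carbon bound to a nitrogen on an aromatic ring and a saturated chain carbon gives a 7.2-fold lower number from compound 2 to compound 3 (0.86 log units; beyond the scatter) and thus stronger inhibition. This shows that the read-out responds to a change in the propylamino chain itself, which the earlier pair, differing only in configuration as drawn, could not show. Nothing in the information given accounts for this step.

From the compounds shown here alone, whether a tert-butyl group, a cyclopropyl group or a longer chain such as pentyl would carry the trend further remains open. Also open, going by these compounds, are the effect of the opposite configuration at the sec-butyl carbon and whether the same methyl change gives a similar step with the configuration of compound 1.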